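The source may report more compounds than this note shows. Statements on the series, on what has been measured and on what is new or still open speak of the compounds shown alone.

Three compounds of one series have been run through an ADME assay on liver for metabolic stability, with Liver microsome (Rattus norvegicus) as the target, read by LC-MS, using microsomes, with a stated time of 5 h; a higher number here means faster removal of the compound, a lower number slower removal. Compound 1 `C[C@]1(O)C[C@](c2cccc(C(F)(F)F)c2)([C@H](O)c2ccccn2)C1` gives 66.7 mL/min/kg. Compound 2 `O[C@H](c1ccccn1)[C@]1(c2cccc(C(F)(F)F)c2)C[C@H](O)C1` gives 183 mL/min/kg. These two differ by a single change, (methyl in place of hydrogen on a saturated ring carbon), and that change produced a 2.7-fold lower number from compound 2 to compound 1 (0.44 log units; beyond the scatter). Compound 3 `O[C@H](c1ccccn1)[C@]1(c2ccc(C(F)(F)F)cc2)C[C@H](O)C1` gives 50 mL/min/kg, a number that lies within the scatter of compound 1 and beyond the scatter from compound 2. Compound 3 is built from the same atoms as compound 2, joined differently; the difference between the two cores is not broken down here.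

Compound 4 `C[C@]1(O)C[C@](c2ccc(C(F)(F)F)cc2)([C@H](O)c2ccccn2)C1` has not yet been measured. Among the measured compounds shown here, it is derived from compound 3 by methyl in place of hydrogen on a saturated ring carbon, the same change at the same place as the one that turns compound 2 into compound 1. Compound 4 is expected to move by a 2.0-fold lower number from compound 3 to compound 4 (0.30 log units; within the scatter). This rests on the earlier pair, where the change gave a 2.7-fold lower number from compound 2 to compound 1 (0.44 log units; beyond the scatter), tempered because compound 3 starts from the lower number 50 mL/min/kg and the change has been seen only once. The estimate for compound 4 in this assay is 25 mL/min/kg, between 12 mL/min/kg and 50 mL/min/kg.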

Compound 4, clearance: 100 mL/min/kg
Compound 4: middle estimate off by 4.0-fold (0.60 log units), on the low side; measured number above the stated range.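

On the core of compound 3, methyl in place of hydrogen on a saturated ring carbon gives a 2.0-fold higher number from compound 3 to compound 4 (0.30 log units; within the scatter) in this assay and so does not repeat the clear fall seen with the same change on the core of compound 1. Carrying this change from one core to the other therefore cannot be taken as a fixed shift in this series, and the two results differ by more than repeated measurement would account for: the same change on two cores in this assay, a 2.7-fold lower number (0.44 log units; beyond the scatter) from compound 2 to compound 1 and a 2.0-fold higher number (0.30 log units; within the scatter) from compound 3 to compound 4, 5.5-fold (0.74 log units) apart, beyond the scatter of two such steps. Among the compounds shown here, with only one pair on each core, this does not show which difference between the cores separates the two results, nor how the change would behave on any further core.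

The compounds shown leave open how an ethyl group or an amine on the same ring carbon would read on either core. They also leave open whether the two cores would part in the same way with a nitrile in place of the trifluoromethyl group.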